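This account rests on a few compounds, and the source may have more. Where it says the series, first, only, none or still open, it means among the compounds named here.

Measured in an ADME assay on L6 cells (Rattus norvegicus) for cytotoxicity, read by resazurin assay; on this read-out lower numbers stand for stronger inhibition and higher numbers for weaker inhibition:
- compound 1 `N=C(N)c1ccc2[nH]c(Nc3ccc(Cl)c(Cl)c3)nc2c1` (39100 nM)
- compound 2 `CCC(C)NC(=N)c1ccc(Nc2nc3cc(C(=N)NC(C)CC)ccc3[nH]2)cc1` (93600 nM)
- compound 3 `N=C(N)c1ccc(Nc2nc3cc(Cl)ccc3[nH]2)cc1` (46400 nM)

Compound 1 sits at the low end of these three numbers. Its value lies within the scatter of that of compound 3 (46400 nM), while compound 2 (93600 nM) stands higher than compound 1, beyond the scatter.

The next compound, compound 4 `N=C(N)c1ccc2[nH]c(Nc3ccc(Cl)cc3)nc2c1`, has not yet been measured. It departs from compound 1 by one change, (hydrogen in place of chloro on an aromatic carbon), which in words is hydrogen in place of chloro on an aromatic carbon. Among the measured compounds shown here, no measured pair of compounds isolates such a change, so the data give no direct size for it. The expectation rests only on the narrow span of values, from compound 1 (39100 nM) to compound 2 (93600 nM). In this assay a small step towards a somewhat higher number is expected, quite possibly none beyond the scatter. The expected change is a 1.3-fold higher number from compound 1 to compound 4 (0.12 log units; within the scatter). The estimate for compound 4 is 52000 nM, with an expected range from 27000 nM to 100000 nM.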

Compound 4, half-maximal inhibitory concentration: 41600 nM
For compound 4 the middle estimate is 1.3-fold (0.10 log units) above the measured one; the measured number falls inside the stated range.
By their numbers in this assay, from the lowest: compounds 1, 4, 3 and 2 (each within the scatter of the next, the first and the last beyond it).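

In this assay, hydrogen in place of chloro on the aromatic carbon ortho to the other chloro group gives a 1.1-fold higher number from compound 1 to compound 4 (0.03 log units; within the scatter), a step within the scatter. Among the compounds shown here, this is the first direct measure of any single change, and it shows that this chloro group can be lost without a step beyond the scatter in this read-out. Nothing measured here accounts for the size of this step.

The compounds shown leave open what a methyl group, an amine or a carboxylic acid would do at this same aromatic carbon, and whether the chloro group that remains in compound 4 could also give way to hydrogen with so small a step. No single-place comparison yet links compound 2 or compound 3 to this pair.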